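Ethyl to isopropyl on the pyrazole arm of compound 3

This account rests on a few compounds, and the source may have more. Where it says the series, first, only, none or still open, it means among the compounds named here.

Compound 1 `CCNC(=O)c1noc(-c2cc(C(C)C)c(O)cc2O)c1-c1cc(CNC(C)=O)no1` in a functional assay on HCT-116 cells (Homo sapiens) for inhibition (a lower number here means a stronger inhibitor, a higher number a weaker inhibitor), gives 167 nM. Compound 2 `CCNC(=O)c1noc(-c2cc(C(C)C)c(O)cc2O)c1-c1cc(CNC(=O)CC)no1` carries methyl in place of hydrogen on a saturated chain carbon bound to a carbonyl carbon and gives 78 nM, a step of a 2.1-fold lower number from compound 1 to compound 2 (0.33 log units; beyond the scatter). Compound 3 `CCNC(=O)c1noc(-c2cc(C(C)C)c(O)cc2O)c1-c1cnn(CC)c1` carries 1-ethyl-1H-pyrazol-4-yl in place of 3-(acetamidomethyl)-1,2-oxazol-5-yl on an aromatic carbon on the shared core of compound 1; in this assay compound 3 gives 26 nM, a step of a 6.4-fold lower number from compound 1 to compound 3 (0.81 log units; beyond the scatter); among the three measured compounds it has the lowest number.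

Compound 4 `CCNC(=O)c1noc(-c2cc(C(C)C)c(O)cc2O)c1-c1cnn(C(C)C)c1` is not yet measured; it carries methyl in place of hydrogen on a saturated chain carbon bound to an aromatic nitrogen and a saturated chain carbon. For the measured compounds named here, this is the same kind of change as the one from compound 1 to compound 2, but the place differs: there the methyl entered on a saturated chain carbon bound to a carbonyl carbon, here on a saturated chain carbon bound to an aromatic nitrogen and a saturated chain carbon, and the cores differ by 1-ethyl-1H-pyrazol-4-yl in place of 3-(acetamidomethyl)-1,2-oxazol-5-yl on an aromatic carbon. A step of about a 1.4-fold lower number from compound 3 to compound 4 (0.16 log units; within the scatter) is expected, resting on the earlier 2.1-fold lower number from compound 1 to compound 2 (0.33 log units; beyond the scatter) with some allowance for the different place. Compound 4 is estimated at 18 nM, between 8 nM and 45 nM.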

Compound 4, half-maximal inhibitory concentration: 21 nM
The estimate for compound 4 lay 1.2-fold (0.07 log units) below the measured number; measured number inside the range.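

In this assay, ethyl to isopropyl gives a 1.2-fold lower number from compound 3 to compound 4 (0.09 log units; within the scatter), while replacing the whole arm with 1-isopropyl-1H-pyrazol-4-yl gives an 8.0-fold lower number from compound 1 to compound 4 (0.90 log units; beyond the scatter). Set beside the earlier methyl step, the new step does not differ from it: the same change on two cores in this assay, a 2.1-fold lower number (0.33 log units; beyond the scatter) from compound 1 to compound 2 and a 1.2-fold lower number (0.09 log units; within the scatter) from compound 3 to compound 4, 1.7-fold (0.24 log units) apart, within the scatter of two such steps. Across these two cores the methyl change therefore carries over without a detectable difference in size, but a single pair on each core, with the methyl at a different place in each, does not establish a general rule for the series.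

Still open, from the compounds shown here alone, is how a longer chain such as n-propyl, or a cyclopropyl ring, would compare with the isopropyl of compound 4. Going by these compounds, the effect of an amine on that chain also remains open.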